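The compounds below may be only part of what the source reports. "The series", "measured", "known", "first", "only" and "open" are said of these compounds alone.

In a functional assay on HepG2 cells (Homo sapiens) for antiproliferative activity, read by MTT assay, with a stated time of 24 h (a higher number here means a weaker inhibitor, a lower number a stronger inhibitor), three compounds sharing one core have been measured. Compound 1 `COc1cc(OC)c(-c2coc3cc(OCC=C(C)C)ccc3c2=O)cc1OC`, with 2-methylprop-1-en-1-yl on the saturated chain carbon, gives 280 nM. Compound 2 `COc1cc(OC)c(-c2coc3cc(OCc4ccccc4C(F)(F)F)ccc3c2=O)cc1OC`, with 2-(trifluoromethyl)phenyl there, gives 6550 nM. Compound 3 `COc1cc(OC)c(-c2coc3cc(OCc4ccccc4C#N)ccc3c2=O)cc1OC`, with 2-cyanophenyl there, is reported only as a limit, > 10000 nM. Its standing is therefore known only as the limit of > 10000 nM in this assay, at which 1 of the 3 values shown sits.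

In compound 4 `COc1cc(OC)c(-c2coc3cc(OCc4cccc(F)c4)ccc3c2=O)cc1OC`, not yet measured, 3-fluorophenyl stands in place of 2-cyanophenyl on a saturated chain carbon bound to an oxygen on an aromatic ring: 3-fluorophenyl in place of 2-cyanophenyl on a saturated chain carbon bound to an oxygen on an aromatic ring. The nearest measured comparison is an at least 1.5-fold higher number from compound 2 to compound 3 (0.18 log units; that floor lies within the scatter), which does not separate the two substituted phenyl groups. The steps away from the 2-methylprop-1-en-1-yl group are much larger, a 23-fold higher number from compound 1 to compound 2 (1.37 log units; beyond the scatter) and an at least 35-fold higher number from compound 1 to compound 3 (1.55 log units; beyond the scatter), and both are large. For the measured compounds named here, no measurement yet shows what 3-fluorophenyl itself does. Compound 4 is nevertheless expected to stay with compound 2 and compound 3 rather than approach compound 1, given the size of an at least 35-fold higher number from compound 1 to compound 3 (1.55 log units; beyond the scatter). The expected change is small and towards a lower number, an estimated at least 2.0-fold lower number from compound 3 to compound 4 (0.30 log units; that floor lies within the scatter). For compound 4 the estimate is 5000 nM, with an expected range of 1500 nM to 15000 nM.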

Compound 4, half-maximal inhibitory concentration: 1230 nM
Compound 4: the middle estimate sits 4.1-fold (0.61 log units) above what was measured; the measured number lies below the stated range.
By their numbers in this assay, from the lowest: compound 1; then compound 4; then compound 2. At a limit, above all of these: compound 3.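

In this assay, for the compounds shown here, the earlier compounds left it unclear whether any aromatic group on this saturated chain carbon could come near the 2-methylprop-1-en-1-yl group, and 3-fluorophenyl narrows that gap to a 4.4-fold higher number from compound 1 to compound 4 (0.64 log units; beyond the scatter) while still not matching compound 1. The aromatic group itself also matters here, which the step from compound 2 to compound 3 could not show: a 5.3-fold lower number from compound 2 to compound 4 (0.73 log units; beyond the scatter) and an at least 8.1-fold lower number from compound 3 to compound 4 (0.91 log units; beyond the scatter) both lie beyond the scatter. Compound 3 remains a limit of the assay, and the second of these steps is only a floor: the limit of > 10000 nM in this assay, at which 1 of the 4 values shown sits.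

The 3-fluorophenyl group differs from 2-cyanophenyl and 2-(trifluoromethyl)phenyl in both its substituent and where that substituent stands, and the compounds shown do not separate these two changes. From the compounds shown here alone, it also remains open how an unsubstituted phenyl group, an amine on the aromatic ring or a longer chain than 2-methylprop-1-en-1-yl would compare at this position.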